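The source may report more compounds than this note shows. Statements on the series, on what has been measured and on what is new or still open speak of the compounds shown alone.

Compound 1 `CC(C)Nc1nc(NCc2ccco2)c2ccccc2n1` is the starting point. In a physicochemical assay for solubility, at pH 7.4 (on this read-out higher numbers stand for higher solubility and lower numbers for lower solubility), compound 1 gives >= 30000 nM, which is a limit of the assay rather than a number; for compound 1 only this limit is known, and the other measured value is a limit as well. Compound 2 `CC(C)Nc1nc(NCc2ccco2)c2cccc(Cl)c2n1` carries a chloro in place of hydrogen on an aromatic carbon. In this assay compound 2 gives <= 5000 nM, again a limit of the assay. Between the two stands an at least 6.0-fold lower number from compound 1 to compound 2 (0.77 log units; beyond the scatter), bounded on each side by the limit of <= 5000 nM in this assay, at which 1 of the 2 values shown sits, and (the limit of >= 30000 nM in this assay, at which 1 of the 2 values shown sits). Compound 3 `CC(C)Nc1nc(NCc2ccco2)c2ccc(Cl)cc2n1` differs from compound 1 by chloro in place of hydrogen on an aromatic carbon. Going by the values given here, the one measured step that bears on this change is the step from compound 1 to compound 2, which points downward by at least a modest margin, so a drop beyond the scatter is expected here as well. Compound 3 is therefore estimated at 8000 nM, with a range from 2000 nM to 30000 nM, which amounts to the expected step of an at least 3.7-fold lower number from compound 1 to compound 3 (0.57 log units; beyond the scatter).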

Compound 3, solubility: <= 20000 nM
Compound 3: no number, only a limit; the forecaster's own chance of this, stated with the estimate: 50%; the middle value lies beyond the limit too.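

In this assay compound 3 gives <= 20000 nM, which is a limit of the assay and not a number. With chloro on this aromatic carbon, meta to a fused ring and para to a fused ring, the data give only an at least 1.5-fold lower number from compound 1 to compound 3 (0.17 log units; that floor lies within the scatter), so no drop beyond the scatter is established at this position. The same change thus shows a drop beyond the scatter only in compound 2, and the step between compound 2 and compound 3 cannot be read, as each value is only a limit.

Going by these compounds, how far the number truly falls at this position, and whether the two chloro positions differ at all, stays open. Also open, on these data alone, is whether a fluoro, a methoxy or an amine on this carbon would behave as chloro does.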